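Notes on aryl exchange and growth inhibition

A few compounds are considered here, and "the series" means these few. Any claim that something is new, unique, unknown or untested is made for them only; others in the source may bear on it.

Measured so far in a functional assay on HL-60 cells (Homo sapiens) for inhibition, read by MTT assay, with a stated time of 48 h, tested at 10 uM; a higher number here means more inhibition of growth at the concentration tested, a lower number less inhibition of growth:
- compound 1 `Cc1oc2c([C@H]3CCN(C)C[C@H]3O)c(O)cc(O)c2c(=O)c1C(O)c1ccc([N+](=O)[O-])cc1`: 0%
- compound 2 `Cc1oc2c([C@H]3CCN(C)C[C@H]3O)c(O)cc(O)c2c(=O)c1C(O)c1c(Cl)cccc1Cl`: 14%

Among the measured compounds shown here, of the two numbers, the one for compound 2 at 14% is the higher, and the gap to compound 1 lies beyond the scatter. The next compound to be read is compound 3 `COc1ccc(C(O)c2c(C)oc3c([C@H]4CCN(C)C[C@H]4O)c(O)cc(O)c3c2=O)cc1Br`, which differs from compound 2 as follows: 3-bromo-4-methoxyphenyl in place of 2,6-dichlorophenyl on a saturated chain carbon bound to an aromatic carbon and an oxygen on a saturated carbon. The shared core stays the same, and only the aryl group changes.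

For the measured compounds named here, one measured step bears on this change, as it is also an aryl exchange at the same place: a number 14 percentage points higher from compound 1 to compound 2 (beyond the scatter). That step is modest. A single step sets no trend, and neither measured compound carries the 3-bromo-4-methoxyphenyl group, so the data give no direction for this exchange. No step beyond the scatter is therefore expected in this assay. The expected change is a number 2 percentage points lower from compound 2 to compound 3 (within the scatter). For compound 3 the estimated value is 12%, with an expected range of 0% to 32%.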

Compound 3, percent growth inhibition at one concentration: 23%
For compound 3 the middle estimate is 11 percentage points below the measured one; low and high end bracket the measured number.
By their numbers in this assay, from the lowest: compound 1; then compounds 2 and 3 (each within the scatter of the next).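

In this assay the exchange of 2,6-dichlorophenyl for 3-bromo-4-methoxyphenyl gives a number 9 percentage points higher from compound 2 to compound 3 (within the scatter) and so does not separate these two aryl groups, although they carry different substituents and the entering group adds a methoxy oxygen as a hydrogen-bond acceptor. Set against the 4-nitrophenyl group, the same new group gives a number 23 percentage points higher from compound 1 to compound 3 (beyond the scatter), which leaves compound 1 as the only one of the three that stands apart from both others, while a reading for a single aryl exchange has become two readings beyond the scatter that share compound 1 as their reference. No measured evidence accounts for any of these steps.

From the compounds shown here alone, all three groups on this saturated chain carbon are substituted phenyl rings, so it remains open whether a pyridine ring, a plain alkyl chain or a phenyl ring bearing an amine or a carboxylic acid would keep this level of growth inhibition. The hydroxyl on that carbon is common to all three compounds, and its replacement by hydrogen or a methyl ether therefore remains an open question as well.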